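Halogen swap at the benzothiazole ring of the chromone series

This account rests on a few compounds, and the source may have more. Where it says the series, first, only, none or still open, it means among the compounds named here.

Compound 1 `Cc1ccc2nc(NCCCCOc3cc(O)c4c(=O)cc(-c5ccccc5)oc4c3)sc2c1` and compound 2 `O=c1cc(-c2ccccc2)oc2cc(OCCCCNc3nc4ccc(Cl)cc4s3)cc(O)c12` share the core and differ only in the substituent on the fused bicycle. In a functional assay on HeLa cells (Homo sapiens) for cytotoxicity, read by sulforhodamine B assay, with a stated time of 48 h (a higher number here means a weaker inhibitor, a lower number a stronger inhibitor), compound 1 gives 6.56 ug/mL and compound 2 gives 5.95 ug/mL. The step of a 1.1-fold lower number from compound 1 to compound 2 (0.04 log units; within the scatter) shows that exchanging methyl for chloro at that aromatic carbon leaves the read-out essentially unchanged. Among the compounds with values here, compound 2 has the lowest of the two numbers so far, with compound 1 within the scatter of it.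

Compound 3 `O=c1cc(-c2ccccc2)oc2cc(OCCCCNc3nc4ccc(I)cc4s3)cc(O)c12` carries the change (iodo in place of chloro on an aromatic carbon). Within the data shown here, only the step from compound 1 to compound 2 bears on it, and it was within the scatter, so a second halogen exchange at the same position is expected to give no step beyond the scatter in this assay, which the estimated step of a 1.1-fold lower number from compound 2 to compound 3 (0.03 log units; within the scatter) expresses. Compound 3 is therefore expected to give about 5.5 ug/mL, in the range 2.8 ug/mL to 11 ug/mL.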

Compound 3, half-maximal inhibitory concentration: 8.12 ug/mL
Estimate against measurement, compound 3: 1.5-fold (0.17 log units) below; measured number inside the range.
By their numbers in this assay, from the lowest: compounds 2, 1 and 3 (each within the scatter of the next).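

Methyl, chloro and iodo now all stand on this aromatic carbon, and this assay does not separate them: iodo in place of chloro gives a 1.4-fold higher number from compound 2 to compound 3 (0.14 log units; within the scatter), and iodo in place of methyl gives a 1.2-fold higher number from compound 1 to compound 3 (0.09 log units; within the scatter). The earlier step compared only methyl with chloro; with iodo added, all three pairs at this position lie within the scatter, a statement limited to these three compounds. Nothing available here accounts for this flat response.

Still open, on these data alone, is whether a group of another kind on this carbon, such as an amine, a carboxylic acid or a nitrile, would give a step beyond the scatter in this assay. Also open, as far as these compounds go, is whether a longer chain linking the shared core to the 1,3-benzothiazol-2-yl amino group would move the number.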